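This account rests on a few compounds, and the source may have more. Where it says the series, first, only, none or still open, it means among the compounds named here.

Working notes on the series. Compound 3 `O=c1ccc(-c2ccc3cn[nH]c3c2)cn1Cc1cccc(C(F)(F)F)c1` stands lowest of the two numbers in hand: in an assay for inhibition of MAP kinase-interacting serine/threonine-protein kinase 2 (Homo sapiens), read by luminescence and ADP-Glo, with a stated time of 2 h (a lower number here means a stronger inhibitor, a higher number a weaker inhibitor), compound 3 gives 32 nM. Compound 1 `NC(=O)c1cccc(Cn2cc(-c3ccc4cn[nH]c4c3)ccc2=O)c1` carries a carbamoyl where compound 3 carries a trifluoromethyl; in this assay compound 1 gives 106 nM. Compound 2 `Cn1ncc2ccc(-c3ccc(=O)n(Cc4ccccc4)c3)cc21` returns only a limit in this assay, > 2000 nM. Compound 2 differs from compound 3 in two places, a methyl on the core nitrogen and an unsubstituted benzyl, so its result is not read as a single step; of the three values shown, one sits at the limit, (the limit of > 2000 nM in this assay, at which 1 of the 3 values shown sits).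

Compound 4 `O=c1ccc(-c2ccc3cn[nH]c3c2)cn1Cc1ccccc1` is the next step: hydrogen in place of trifluoromethyl on an aromatic carbon. Among the measured compounds shown here, the only measured step at that position is a 3.3-fold lower number from compound 1 to compound 3 (0.52 log units; beyond the scatter), which exchanges one substituent for another on the benzyl ring; no measured step removes the substituent altogether. Taking that modest step as the scale of what a change at the position meta to a large group does, the number for compound 4 is expected to rise, beyond the scatter but not by much, and a limit is not expected. The expected step is a 2.8-fold higher number from compound 3 to compound 4 (0.45 log units; beyond the scatter). Compound 4 is estimated at 90 nM in this assay, with a range from 30 nM to 300 nM.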

Compound 4, half-maximal inhibitory concentration: 75 nM
Beside the measured number, compound 4's estimate is 1.2-fold (0.08 log units) above it, and the stated range covers the measured number.
By their numbers in this assay, from the lowest: compound 3; then compounds 4 and 1 (each within the scatter of the next). At a limit, above all of these: compound 2.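

In this assay, among the compounds shown here, the unsubstituted benzyl of compound 4 gives the first direct reading of what trifluoromethyl contributes at this aromatic carbon, and the contribution is limited: a 2.3-fold higher number from compound 3 to compound 4 (0.37 log units; beyond the scatter). The carbamoyl shows no separation from hydrogen at the same place, a 1.4-fold lower number from compound 1 to compound 4 (0.15 log units; within the scatter), so among the three groups read here only trifluoromethyl stands apart from the other two, and the unsubstituted ring does not fall to a limit. The change at the core is much larger than any seen on the benzyl ring, with hydrogen in place of methyl on an aromatic nitrogen giving an at least 26-fold lower number from compound 2 to compound 4 (1.42 log units; beyond the scatter), but this size is only a bound, as compound 2 gives a limit and not a number: the limit of > 2000 nM in this assay, at which 1 of the 4 values shown sits.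

The compounds shown leave open whether a chlorine, a methoxy or a carboxylic acid at this aromatic carbon would stand with trifluoromethyl or with hydrogen and carbamoyl. They also leave open how an ethyl or a longer chain on the aromatic nitrogen would read, and whether trifluoromethyl gives a similar step at another carbon of the benzyl ring.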